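The source may hold more compounds than are shown below. What is called first, only, known or untested is meant among the compounds shown, and "the series" means these compounds.

Measured so far in an ADME assay on MRC5 cells (Homo sapiens) for antiproliferative activity, read by fluorescence and resazurin assay, with a stated time of 68 h; a higher number here means that more compound is needed for the effect, a lower number that less compound is needed
compound 1 `Cc1ccc(-c2cc(C(=O)Nc3cccnc3)c3cc(Cl)ccc3n2)cc1` gives 21000 nM
compound 2 `Cc1ccc(-c2cc(C(=O)Nc3cccnc3)c3cc(F)ccc3n2)cc1` gives 50000 nM

Compound 1 at 21000 nM holds the lower of the two numbers. The next compound is compound 3 `Cc1ccc(-c2cc(C(=O)NCCN3CCCCC3)c3cc(Cl)ccc3n2)cc1` with the change 2-(piperidin-1-yl)ethyl in place of pyridin-3-yl on an amide-type nitrogen in which 2-(piperidin-1-yl)ethyl replaces pyridin-3-yl on an amide-type nitrogen. Within the data shown here, the one measured step is a 2.4-fold higher number from compound 1 to compound 2 (0.38 log units; beyond the scatter) for fluoro in place of chloro on an aromatic carbon. That step does not involve the amide-type nitrogen and gives only a rough sense of size. Among the measured compounds shown here, no measured step shows the effect of the amide change in this assay so the direction is poorly fixed. A small move toward a lower number is tentatively expected. The estimated step is a 1.8-fold lower number from compound 1 to compound 3 (0.24 log units; within the scatter) with wide uncertainty. For compound 3 the value is estimated at 12000 nM within an expected range of 3500 nM to 40000 nM for now.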

Compound 3, half-maximal effective concentration: 7000 nM
Estimate against measurement, compound 3: 1.7-fold (0.23 log units) above, and the stated range covers the measured number.
By their numbers in this assay, from the lowest: compound 3; then compound 1; then compound 2.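

On the amide-type nitrogen, 2-(piperidin-1-yl)ethyl in place of pyridin-3-yl gives a 3.0-fold lower number from compound 1 to compound 3 (0.48 log units; beyond the scatter) in this assay, so a single change at this place moves the number beyond the scatter. The step swaps a six-membered aromatic ring for a six-membered non-aromatic ring and adds the ethyl link, and these parts cannot be separated with the compounds shown. No measured evidence bears on why the number falls.

Still open, on these data alone, is whether a longer chain between the amide-type nitrogen and the ring, a morpholine ring or an open-chain dimethylamino group would hold the lower number seen for compound 3. As far as these compounds go, it is also open whether fluoro in place of chloro on the aromatic carbon has the same effect when 2-(piperidin-1-yl)ethyl is present.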